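Swapping an Ethoxy Group for Dimethylamino

This account rests on a few compounds, and the source may have more. Where it says the series, first, only, none or still open, it means among the compounds named here.

Compound 3 `CCOc1ccc(-c2cccc(NC(=O)N(C)C)c2)cc1` stands second highest of the three measured compounds in an assay on COS-7 cells for inhibition of patatin-like phospholipase domain-containing protein 2 (Mus musculus), tested at 200 uM (a lower number here means less inhibition, a higher number more inhibition at the concentration tested (going by the name of the read-out)), giving 68%. Compound 1 `CCOc1ccc(-c2cccc(C(=O)OCCOC)c2)cc1` gives 89%, and compound 2 `CCOc1ccc(-c2cccc(NC(C)=O)c2)cc1` gives 52%; the step of a number 16 percentage points higher from compound 2 to compound 3 (beyond the scatter) is modest, while a number 21 percentage points lower from compound 1 to compound 3 (beyond the scatter) and a number 37 percentage points lower from compound 1 to compound 2 (beyond the scatter) are larger drops. Compound 4 `CN(C)C(=O)Nc1cccc(-c2ccc(N(C)C)cc2)c1` differs from compound 3 by dimethylamino in place of ethoxy on an aromatic carbon. For the measured compounds named here, none of the measured steps touches this part of the molecule: all three change a different group, so none bears directly on the change at hand. With no guidance from the data, the expected step of a number 2 percentage points lower from compound 3 to compound 4 (within the scatter) is none beyond the scatter. Compound 4 is therefore estimated to give 66%, with a likely range from 45% to 85%.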

Compound 4, a percentage reported as inhibition, at one concentration (the size of the read-out at that concentration, not a potency): 98%
The estimate for compound 4 lay 32 percentage points below the measured number, outside the stated range (above it).
By their numbers in this assay, from the lowest: compound 2; then compound 3; then compounds 1 and 4 (each within the scatter of the next).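

In this assay, the position para to a large group proves sensitive, as dimethylamino in place of ethoxy gives a number 30 percentage points higher from compound 3 to compound 4 (beyond the scatter). The two groups match in heavy atoms, hydrogen-bond donors and hydrogen-bond acceptors, so these counts do not separate them. No available evidence accounts for the rise.

On these data alone, it remains open whether a primary amine, a pyrrolidine ring or a longer chain such as diethylamino would give a similar number at this position. As far as these compounds go, whether dimethylamino has a similar effect on compound 1 or compound 2 also remains open.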